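Aryl ether exchange carried onto the tetrahydroisoquinoline core

A few compounds are considered here, and "the series" means these few. Any claim that something is new, unique, unknown or untested is made for them only; others in the source may bear on it.

Compound 1 `c1cc(N2CCCCC2)nc(Nc2ccc(Oc3ncnc4sccc34)cc2)n1` gives 4020 nM in a functional assay on A549 cells (Homo sapiens) for inhibition, read by MTT assay, with a stated time of 72 h; a lower number here means a stronger inhibitor, a higher number a weaker inhibitor. Compound 2 `CNC(=O)c1cc(Oc2ccc(Nc3nccc(N4CCCCC4)n3)cc2)ccn1` differs from compound 1 by a group of 10 heavy atoms (7 carbon, 2 nitrogen, 1 oxygen; one six-membered aromatic ring with 1 hetero atom) in place of a group of 9 heavy atoms (6 carbon, 2 nitrogen, 1 sulfur; one five-membered aromatic ring with 1 hetero atom, one six-membered aromatic ring with 2 hetero atoms), on an oxygen on an aromatic ring; in this assay compound 2 gives 890 nM, and the step is a 4.5-fold lower number from compound 1 to compound 2 (0.65 log units; beyond the scatter). Compound 3 `c1ccc2c(c1)CCN(c1ccnc(Nc3ccc(Oc4ncnc5sccc45)cc3)n1)C2` carries the second core of the series, differing from compound 1 by 1,2,3,4-tetrahydroisoquinolin-2-yl in place of piperidin-1-yl on an aromatic carbon; in this assay compound 3 gives 6750 nM, and the step is a 1.7-fold higher number from compound 1 to compound 3 (0.23 log units; within the scatter), so the two cores are not separated by this assay. Compound 4 `CNC(=O)c1cc(Oc2ccc(Nc3nccc(N4CCc5ccccc5C4)n3)cc2)ccn1` has not been measured. It differs from compound 3 by a group of 10 heavy atoms (7 carbon, 2 nitrogen, 1 oxygen; one six-membered aromatic ring with 1 hetero atom) in place of a group of 9 heavy atoms (6 carbon, 2 nitrogen, 1 sulfur; one five-membered aromatic ring with 1 hetero atom, one six-membered aromatic ring with 2 hetero atoms), on an oxygen on an aromatic ring. The surroundings of the exchanged group are described in the same words for both pairs, so this is the same change as that from compound 1 to compound 2, made on the other core; the cores themselves differ only as set out above for compound 1 and compound 3.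

The earlier step, a 4.5-fold lower number from compound 1 to compound 2 (0.65 log units; beyond the scatter), is the guide here. The step from compound 3 to compound 4 in this assay is expected to be of about the same size, with some allowance for the core not being identical. For compound 4 the expected step is a 4.5-fold lower number from compound 3 to compound 4 (0.65 log units; beyond the scatter), resting on the step of a 4.5-fold lower number from compound 1 to compound 2 (0.65 log units; beyond the scatter) seen with compound 1 and compound 2 and on the value of compound 3. Compound 4 is therefore estimated at 1500 nM in this assay, with a range from 700 nM to 3500 nM.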

Compound 4, half-maximal inhibitory concentration: 3190 nM
Compound 4: the middle estimate sits 2.1-fold (0.33 log units) below what was measured, and the stated range covers the measured number.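

In this assay, the exchange to 2-(methylcarbamoyl)pyridin-4-yl on the oxygen on an aromatic ring gives a 2.1-fold lower number from compound 3 to compound 4 (0.33 log units; beyond the scatter) on the core of compound 3, the same direction as on the core of compound 1, and the two steps do not separate: the same change on two cores in this assay, a 4.5-fold lower number (0.65 log units; beyond the scatter) from compound 1 to compound 2 and a 2.1-fold lower number (0.33 log units; beyond the scatter) from compound 3 to compound 4, 2.1-fold (0.33 log units) apart, within the scatter of two such steps

The reverse reading agrees, as the core exchange gives a 1.7-fold higher number from compound 1 to compound 3 (0.23 log units; within the scatter) with the original ether group and a 3.6-fold higher number from compound 2 to compound 4 (0.55 log units; beyond the scatter) with 2-(methylcarbamoyl)pyridin-4-yl in place, and these two steps do not separate either: the same change on two cores in this assay, a 1.7-fold higher number (0.23 log units; within the scatter) from compound 1 to compound 3 and a 3.6-fold higher number (0.55 log units; beyond the scatter) from compound 2 to compound 4, 2.1-fold (0.33 log units) apart, within the scatter of two such steps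

The four compounds therefore fit a change that carries from one core to the other, but this rests on a single square of compounds in one cell assay, so it does not show that the size of the step is the same on both cores, nor does it rule out a modest dependence on the core.

On these data alone, it remains open whether the exchange carries over to cores bearing another amine on the aromatic carbon, such as morpholin-4-yl or an open-chain dialkylamine. Also open, as far as these compounds go, is whether the methylcarbamoyl group itself matters, which a primary amide or a carboxylic acid in its place would begin to address.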